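The source may report more compounds than this note shows. Statements on the series, on what has been measured and on what is new or still open speak of the compounds shown alone.

Measured so far:
- compound 1, `O=C1C=C(NCc2ccccc2)C(=O)c2c1nc1n2[C@H]2OC[C@@H](O)[C@H]2OC1`: 2670 nM
- compound 2, `Cc1ccc(NC2=CC(=O)c3c(nc4n3[C@H]3OC[C@@H](O)[C@H]3OC4)C2=O)cc1`: 1550 nM
- compound 3, `O=C1C(N2CCCC2)=CC(=O)c2c1nc1n2[C@H]2OC[C@@H](O)[C@H]2OC1`: > 16000 nM

In a functional assay on MGC-803 cells (Homo sapiens) for inhibition, read by sulforhodamine B assay (on this read-out lower numbers stand for stronger inhibition and higher numbers for weaker inhibition), compound 1 gives 2670 nM, and compound 2 gives 1550 nM; these two numbers lie within the usual scatter of each other, so they cannot be told apart. Compound 3 reaches only the limit of this assay, > 16000 nM, which is not a number. Among the measured compounds shown here, the one measured step, an at least 10-fold higher number from compound 2 to compound 3 (1.01 log units; beyond the scatter), shows that the group on the amine nitrogen can change the result greatly, as the value of compound 3 sits at the limit of > 16000 nM in this assay, at which 1 of the 3 values shown sits.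

The unmeasured compound 4, `COc1ccc(NC2=CC(=O)c3nc4n(c3C2=O)[C@H]2OC[C@@H](O)[C@H]2OC4)cc1`, differs from compound 1 in one place: 4-methoxyphenyl in place of benzyl on an amine nitrogen. Compound 2 also carries an aromatic ring directly on that nitrogen, as (4-methylphenyl)amino, and its number lies within the scatter of compound 1. For the measured compounds named here, no measured step covers the change from benzylamino to (4-methoxyphenyl)amino itself, so no large shift is expected. For compound 4 the estimated value is 1800 nM, with a range of 700 nM to 4800 nM. The expected step is therefore a 1.5-fold lower number from compound 1 to compound 4 (0.17 log units; within the scatter), within the scatter.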

Compound 4, half-maximal inhibitory concentration: 1680 nM
The estimate for compound 4 lay 1.1-fold (0.03 log units) above the measured number; low and high end bracket the measured number.
By their numbers in this assay, from the lowest: compounds 2, 4 and 1 (each within the scatter of the next). At a limit, above all of these: compound 3.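

Putting 4-methoxyphenyl in place of benzyl on the amine nitrogen gives a 1.6-fold lower number from compound 1 to compound 4 (0.20 log units; within the scatter) in this assay, so this swap cannot be told apart from the ordinary spread of repeated measurements. This amine nitrogen can therefore carry either an aromatic ring attached through a carbon, as in benzyl, or one attached directly, as in 4-methoxyphenyl, with no readable difference, and the hydrogen-bond acceptor that enters with 4-methoxyphenyl brings none either. Nothing among the data shown explains why this change leaves the number so little altered.

Still open, as far as these compounds go, is whether a longer chain on this nitrogen, such as 2-phenylethyl, would give a readable step. So is whether a carboxylic acid or a dimethylamino group in place of the methoxy group would do so.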